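The source may report more compounds than this note shows. Statements on the series, on what has been measured and on what is new or still open speak of the compounds shown alone.

Of the compounds shown here, three built on a shared core have been tested in an assay on HEK293 cells for agonist activity at Toll-like receptor 8 (Homo sapiens), read by spectrophotometry; on this read-out higher numbers stand for an effect only at larger amounts of compound and lower numbers for an effect already at smaller amounts. Compound 1 `CCCCNc1nc(N)nc(C)c1CCCN1CCCCC1` carries a piperidin-1-yl group at the end of a saturated chain and, in this assay, compound 1 gives 133 nM. Compound 2 `CCCCNc1nc(N)nc(C)c1CCCn1c(C)nc2ccccc21` gives 366 nM, and compound 3 `CCCCNc1nc(N)nc(C)c1CCCn1ccc2ccccc21` gives 1100 nM. Among these three numbers compound 1 stands lowest: the gap to compound 2 is the nearest but already lies beyond the usual scatter, and the gap to compound 3 is the widest and clearly beyond it. Compound 4 `CCCCNc1nc(N)nc(C)c1CCCn1cncn1` has not been measured yet. It differs from compound 1 in one place: 1H-1,2,4-triazol-1-yl in place of piperidin-1-yl on a saturated chain carbon, three bonds along the chain from an aromatic carbon. For the measured compounds named here, no measured pair shows exactly this exchange, so the expectation rests on the pattern that the two compounds with an aromatic group on that chain, compound 2 at 366 nM and compound 3 at 1100 nM, give higher numbers than compound 1. The step is expected to be a 4.5-fold higher number from compound 1 to compound 4 (0.65 log units; beyond the scatter), towards a higher number, beyond the scatter. Compound 4 is therefore estimated at 600 nM, with a likely range from 200 nM to 2000 nM.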

Compound 4, half-maximal effective concentration: 1050 nM
The estimate for compound 4 lay 1.8-fold (0.24 log units) below the measured number; the range from low to high includes it.
By their numbers in this assay, from the lowest: compound 1; then compound 2; then compounds 4 and 3 (each within the scatter of the next).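

In this assay, for the compounds shown here, this exchange gives a 7.9-fold higher number from compound 1 to compound 4 (0.90 log units; beyond the scatter), the first step at this position that changes only one group, and it shows that the end of the saturated chain is sensitive to what sits there. The higher number seen with the aromatic groups of compound 2 and compound 3 also appears with the five-membered aromatic 1H-1,2,4-triazol-1-yl. However, ring size, aromatic character and hetero atoms all change together in this single step, and nothing available here separates their contributions or explains the result. On these data alone, it remains open whether pyrrolidin-1-yl, a non-aromatic five-membered ring, or morpholin-4-yl, a six-membered ring with an added oxygen, would give a number close to that of compound 1 at 133 nM in this assay. As far as these compounds go, the effect of a longer chain carrying piperidin-1-yl also remains open.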